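The source may report more compounds than this note shows. Statements on the series, on what has been measured and on what is new or still open speak of the compounds shown alone.

Measured so far:
compound 1, `COc1cc(Nc2nc(C(=N)Nc3ccc(N4CCN(C)CC4)cc3)cc3c(-c4ccccc4)n[nH]c23)cc(OC)c1OC`, 4300 nM in a functional assay on PC-3 cells (Homo sapiens) for cytotoxicity, read by MTT assay, with a stated time of 72 h; a lower number here means a stronger inhibitor, a higher number a weaker inhibitor
compound 2, `CN1CCN(c2ccc(NC(=N)c3cc4c(-c5ccccc5)n[nH]c4c(NC4CCCCC4)n3)cc2)CC1`, 4630 nM in this assay
compound 3, `COc1ccc(Cn2nc(-c3ccccc3)c3cc(C(=N)Nc4ccccc4)nc(NC4CCCCC4)c32)cc1`, 1100 nM in this assay

Compound 3 gives the lowest number of the three; its gaps to compound 1 and to compound 2 lie beyond the usual scatter. How the core of compound 3 differs from the core of compound 2 is not broken down here.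

Compound 4, `COc1ccc(Cn2nc(-c3ccccc3)c3cc(C(=N)Nc4ccccc4)nc(Nc4cc(OC)c(OC)c(OC)c4)c32)cc1`, has not yet been measured in this assay. It differs from compound 3 in one place:
3,4,5-trimethoxyphenyl in place of cyclohexyl on a nitrogen on an aromatic ring

The same change has already been made once, from compound 2 to compound 1:
3,4,5-trimethoxyphenyl in place of cyclohexyl on a nitrogen on an aromatic ring
There it gave a 1.1-fold lower number from compound 2 to compound 1 (0.03 log units; within the scatter).

Because that step a 1.1-fold lower number from compound 2 to compound 1 (0.03 log units; within the scatter) stayed within the scatter, the step from compound 3 to compound 4 is expected to be about as small, namely a 1.1-fold lower number from compound 3 to compound 4 (0.04 log units; within the scatter). This rests on one pair only, so the expectation is loose. Compound 4 is therefore estimated at 1000 nM in this assay, with a range from 450 nM to 2500 nM.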

Compound 4, half-maximal inhibitory concentration: 50000 nM
The estimate for compound 4 lay 50-fold (1.70 log units) below the measured number; the whole stated range lies below it.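

In this assay, putting 3,4,5-trimethoxyphenyl in place of cyclohexyl gave a 45-fold higher number from compound 3 to compound 4 (1.66 log units; beyond the scatter), whereas the same swap made almost no difference on the other core. The outcome of this change therefore does not carry from one core to another in this series, and a result on one core is a poor guide to the other: the same change on two cores in this assay, a 1.1-fold lower number (0.03 log units; within the scatter) from compound 2 to compound 1 and a 45-fold higher number (1.66 log units; beyond the scatter) from compound 3 to compound 4, 49-fold (1.69 log units) apart, beyond the scatter of two such steps

Going by these compounds alone, this does not show which feature of the cores matters, as the two pairs differ from each other in more than one place, and each core offers only a single example of the change.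

As far as these compounds go, it remains open whether a compound differing from compound 3 in just one of those places would behave like compound 3 or like compound 2 when the swap is made. Also open, from the compounds shown here alone, is how a simple butyl chain or a pyridyl group on that nitrogen would compare with cyclohexyl and 3,4,5-trimethoxyphenyl on the core of compound 3.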